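Replacing Pyridin-3-yl with 3-Chlorophenyl in Aromatase Binding

The source may hold more compounds than are shown below. What is called first, only, known or untested is meant among the compounds shown, and "the series" means these compounds.

Compound 1 `N#Cc1ccc(-n2ccc3ccncc32)cc1Oc1ccccc1` gives 97% in an assay on isolated protein for inhibition of Aromatase (Homo sapiens), read by fluorescence, tested at 1 uM; a higher number here means more inhibition at the concentration tested (going by the name of the read-out), a lower number less inhibition.
Compound 2 `N#Cc1ccc(Oc2cccnc2)c(Oc2cccnc2)c1` gives 82% in this assay.
Compound 3 `N#Cc1ccc(Oc2cccnc2)c(F)c1` gives 52% in this assay.

Compound 2 stands second of the three: compound 1 is higher and compound 3 lower, both beyond the scatter. Compound 4 `N#Cc1ccc(Oc2cccnc2)c(Oc2cccc(Cl)c2)c1` keeps the core of compound 2 but changes one group: 3-chlorophenyl in place of pyridin-3-yl on an oxygen on an aromatic ring. Among the compounds with values here, only one measured step bears on this place, a number 30 percentage points lower from compound 2 to compound 3 (beyond the scatter), where the whole (pyridin-3-yl)oxy group gave way to fluoro and cost a modest amount. Here the oxygen-linked ring is retained, so the change is smaller; nothing measured tells what removing the pyridine ring nitrogen alone does. A modest drop, a number 22 percentage points lower from compound 2 to compound 4 (beyond the scatter), is expected, giving compound 4 an estimated 60%, in the range 30% to 85%.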

Compound 4, a percentage reported as inhibition, at one concentration (the size of the read-out at that concentration, not a potency): 89%
Compound 4: the middle estimate sits 29 percentage points below what was measured, outside the stated range (above it).
By their numbers in this assay, from the lowest: compound 3; then compounds 2, 4 and 1 (each within the scatter of the next, the first and the last beyond it).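

Putting 3-chlorophenyl in place of pyridin-3-yl on this oxygen gives a number 7 percentage points higher from compound 2 to compound 4 (within the scatter) in this assay. The loss seen with fluoro, a number 30 percentage points lower from compound 2 to compound 3 (beyond the scatter), therefore does not recur when an oxygen-linked ring stays at this place, even without the ring nitrogen of pyridin-3-yl. Nothing available explains why the two rings read alike. The compounds shown leave open whether an amine or a carboxylic acid in place of the chlorine would hold the number, and whether compound 2 and compound 4 would still read alike at other concentrations.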